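Ester to benzyl ether on the aromatic oxygen

This account rests on a few compounds, and the source may have more. Where it says the series, first, only, none or still open, it means among the compounds named here.

Compound 1 `COc1ccc2c(=O)c(-c3cc(OC)c(OC)cc3OC)coc2c1` carries a methyl on the oxygen on the aromatic ring; in a functional assay on HepG2 cells (Homo sapiens) for antiproliferative activity, read by MTT assay, with a stated time of 24 h (on this read-out higher numbers stand for weaker inhibition and lower numbers for stronger inhibition), compound 1 gives 2040 nM. Compound 2 `COc1cccc(C(=O)Oc2ccc3c(=O)c(-c4cc(OC)c(OC)cc4OC)coc3c2)c1` carries a (3-methoxyphenyl)carbonyl on that oxygen instead. In this assay compound 2 reaches only a limit, > 10000 nM, and no number is known for it. The step of an at least 4.9-fold higher number from compound 1 to compound 2 (0.69 log units; beyond the scatter) is accordingly itself only a limit, set by the limit of > 10000 nM in this assay, at which 1 of the 2 values shown sits. Compound 3 `COc1cc(OC)c(-c2coc3cc(OCc4ccc(C#N)cc4)ccc3c2=O)cc1OC` differs from compound 2 as follows: 4-cyanobenzyl in place of (3-methoxyphenyl)carbonyl on an oxygen on an aromatic ring. No measured step covers a 4-cyanobenzyl on this oxygen; the one step shown, from compound 1 to compound 2, runs toward weaker inhibition, and how far past the limit compound 2 lies is unknown. The step of an at least 2.0-fold lower number from compound 2 to compound 3 (0.30 log units; that floor lies within the scatter) is therefore the expected step, its size uncertain from the limit side. Compound 3 is estimated at 5000 nM, within a range of 1500 nM to 16000 nM.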

Compound 3, half-maximal inhibitory concentration: 4230 nM
Compound 3: middle estimate off by 1.2-fold (0.07 log units), on the high side; measured number inside the range.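

In this assay, a group much larger than methyl on the oxygen on the aromatic ring can still give a measurable number, with an at least 2.3-fold lower number from compound 2 to compound 3 (0.37 log units; beyond the scatter). Compound 2 gives > 10000 nM, which is a limit, so this step is only a floor and its true size cannot be read: the limit of > 10000 nM in this assay, at which 1 of the 3 values shown sits. Methyl still gives the stronger inhibition of the groups compared here, with a 2.1-fold higher number from compound 1 to compound 3 (0.32 log units; beyond the scatter).

The change from (3-methoxyphenyl)carbonyl to 4-cyanobenzyl alters the link to the oxygen and the substituent on the ring in a single step, and the compounds shown do not separate the two. Open on this oxygen are an unsubstituted benzyl, a 4-methoxybenzyl, a chain ending in an amine and a free hydroxyl.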